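The compounds below may be only part of what the source reports. "The series", "measured", "known", "first", "only" and "open" are said of these compounds alone.

Compound 1 `CC(C)(C)CNC(=O)C[C@H](NC(=O)CN1CCCCC1)C(=O)N[C@@H](CCc1ccccc1)C(=O)NCc1ccccc1`: in an assay on HEK293 cells for inhibition of nuclear factor NF-kappa-B complex (Homo sapiens), read by a luciferase reporter, with stated times of 1 h and 3 h (on this read-out higher numbers stand for weaker inhibition and lower numbers for stronger inhibition), compound 1 gives 62 nM.
Compound 2 `CC(C)(C)CNC(=O)C[C@H](NC(=O)c1ccc(C(C)(C)C)cc1)C(=O)N[C@@H](CCc1ccccc1)C(=O)NCc1ccccc1`: in this assay compound 2 gives 32 nM.

Among the two measured compounds, compound 2 has the lowest number, but its nearest neighbour is compound 1, and the step of a 1.9-fold lower number from compound 1 to compound 2 (0.29 log units; within the scatter) lies within the scatter, so the two cannot be ranked against each other.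

Compound 3 `CC(C)(C)CNC(=O)C[C@H](NC(=O)C(=O)c1c[nH]c2ccccc12)C(=O)N[C@@H](CCc1ccccc1)C(=O)NCc1ccccc1` has not yet been measured. It differs from compound 2 in one place: (1H-indol-3-yl)carbonyl in place of 4-(tert-butyl)phenyl on a carbonyl carbon. Going by the values given here, the only measured step that touches this same place is a 1.9-fold lower number from compound 1 to compound 2 (0.29 log units; within the scatter), where one cap on that carbonyl carbon was exchanged for another and the number hardly moved. Among the compounds with values here, no measured compound carries the group that enters here, so nothing shows how this particular cap behaves. Within the data shown here, the one step available suggests that changing the cap at this carbonyl carbon changes little, and the expectation for compound 3 is therefore a step of a 1.3-fold higher number from compound 2 to compound 3 (0.10 log units; within the scatter), which is no change beyond the scatter. On that basis compound 3 is estimated at 40 nM in this assay, with a range from 12 nM to 130 nM.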

Compound 3, half-maximal inhibitory concentration: 25 nM
Estimate against measurement, compound 3: 1.6-fold (0.20 log units) above; low and high end bracket the measured number.
By their numbers in this assay, from the lowest: compounds 3, 2 and 1 (each within the scatter of the next, the first and the last beyond it).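

In this assay, (1H-indol-3-yl)carbonyl and 4-(tert-butyl)phenyl cannot be told apart on this carbonyl carbon, a 1.3-fold lower number from compound 2 to compound 3 (0.11 log units; within the scatter), so a cap with a hydrogen-bond donor and a hydrogen-bond acceptor performs on a par with one that has neither. Going by these compounds alone, the comparison with the piperidine-containing cap gives the first step at this position that clears the scatter, a 2.5-fold lower number from compound 1 to compound 3 (0.39 log units; beyond the scatter), though this change is only modest, and compound 2 remains within the scatter of both compound 1 and compound 3, so the three caps do not form three separate levels. Nothing available explains why the indole-containing cap gives this result.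

The compounds shown leave open whether the hydrogen on the indole nitrogen matters, which a 1-methyl-1H-indol-3-yl group would test, and whether the added carbonyl matters, which a 1H-indol-3-yl group without it would test. They also do not show how a much smaller cap such as methyl, or one carrying a carboxylic acid, would behave on this carbonyl carbon.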